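A ring methyl added to a compound at the limit

The source may hold more compounds than are shown below. What is called first, only, known or untested is meant among the compounds shown, and "the series" means these compounds.

In a functional assay on the whole organism for agonist activity, with Mus musculus as the target (on this read-out higher numbers stand for an effect only at larger amounts of compound and lower numbers for an effect already at smaller amounts), compound 1 (`CC(=O)N(C)C(C)C#CCn1ccnc1`) gives 3 mg/kg as a true measured number. Compound 3 (`CC(C#CCn1ccnc1)N1CCCC1=O`) reads > 100 mg/kg, which is a limit of the assay and not a number. On these data alone, compound 3 therefore stands at the limit of > 100 mg/kg in this assay, at which 2 of the 3 values shown sit, and its true position is unknown.

Compound 4 (`Cc1cncn1CC#CC(C)N1CCCC1=O`) differs from compound 3 by a single change, a methyl in place of hydrogen on an aromatic carbon.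

Among the measured compounds shown here, one measured step bears on this change. Compound 2 (`CC(=O)N(C)C(C)C#CCn1ccnc1C`) reads > 100 mg/kg, again a limit of the assay. It too carries a methyl in place of hydrogen on an aromatic carbon, and that swap gave an at least 33-fold higher number from compound 1 to compound 2 (1.52 log units; beyond the scatter), a large move towards needing more compound. The methyl of compound 4 sits on a different ring carbon, and compound 3 has a different amide part, so this single pair is only a loose guide.

Going by an at least 33-fold higher number from compound 1 to compound 2 (1.52 log units; beyond the scatter) as the only precedent, no drop in the number is expected. The expected step is a step that the limit leaves unreadable from compound 3 to compound 4, a small one with no direction that could be read past the limit. Compound 4 is estimated at 150 mg/kg, with an expected range from 40 mg/kg to 500 mg/kg, and it will probably be reported only as a limit.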

Compound 4, dose for half-maximal effect: > 100 mg/kg
Compound 4: no number, only a limit (the forecaster's own chance of this, stated with the estimate: 85%); the middle value does not contradict the limit.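

Compound 3 and compound 4 both read as a limit of the assay and not as a true number, so no step between them can be read: the limit of > 100 mg/kg in this assay, at which 3 of the 4 values shown sit.

The compounds shown leave open how much of compound 3 or compound 4 is truly needed for an effect, and whether this methyl in place of hydrogen changes that amount at all.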